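The compounds below may be only part of what the source reports. "The series", "measured", "known", "first", "only" and "open" are said of these compounds alone.

Compound 2 `COc1cc2nccc(Oc3ccc(Nc4nn(C)cc4C(=O)N4CCCCC4)cc3)c2cc1C(N)=O` carries a piperidin-1-yl group on the carbonyl carbon, and in a functional assay on BaF3 cells (Mus musculus) for antiproliferative activity, read by CCK-8 assay and cell counting, with a stated time of 76 h (a lower number here means a stronger inhibitor, a higher number a weaker inhibitor), compound 2 gives 5650 nM, the higher of the two finite numbers available. Compound 3 `COc1cc2nccc(Oc3ccc(Nc4nn(C)cc4C(=O)Nc4ccc(F)cc4)cc3)c2cc1C(N)=O` gives 3060 nM in this assay. The change there is a 1.8-fold lower number from compound 2 to compound 3 (0.27 log units; within the scatter). Compound 1 `COc1cc2nccc(Oc3ccc(Nc4nn(C)cc4C(=O)Nc4ccccc4)cc3)c2cc1C(N)=O` reaches only a limit of the assay, > 10000 nM (the limit of > 10000 nM in this assay, at which 1 of the 3 values shown sits). Compound 4 `COc1cc2nccc(Oc3ccc(Nc4nn(C)cc4C(=O)NOCc4ccccc4)cc3)c2cc1C(N)=O` differs from compound 2 at the same carbonyl carbon: (benzyloxy)amino in place of piperidin-1-yl on a carbonyl carbon. The two steps that touch this position are both small: an at least 1.7-fold lower number from compound 1 to compound 2 (0.24 log units; that floor lies within the scatter) and a 1.8-fold lower number from compound 2 to compound 3 (0.27 log units; within the scatter). Against that background a step near the scatter is expected for compound 4, while the limit shown by compound 1 leaves room for a weaker outcome. The expected step is a 1.1-fold higher number from compound 2 to compound 4 (0.03 log units; within the scatter). Compound 4 is estimated at 6000 nM, between 2000 nM and 18000 nM.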

Compound 4, half-maximal inhibitory concentration: > 10000 nM
Compound 4: no number, only a limit; the forecaster's own chance of this, stated with the estimate: 25%; middle value at least 1.6-fold (0.22 log units) away from the limit.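

In this assay, (benzyloxy)amino in place of piperidin-1-yl on the carbonyl carbon gives an at least 1.7-fold higher number from compound 2 to compound 4 (0.24 log units; that floor lies within the scatter), so this change shows no gain. The clearer contrast is an at least 3.2-fold higher number from compound 3 to compound 4 (0.51 log units; beyond the scatter), which shows that the group on the amide-type nitrogen can move the result beyond the scatter. Compound 4 gives only a limit, as does compound 1, so the step between them cannot be read: the limit of > 10000 nM in this assay, at which 2 of the 4 values shown sit.

Still open, on these data alone, is how far compound 4 lies past its limit. Also open, as far as these compounds go, is whether benzylamino, which lacks the oxygen of (benzyloxy)amino, would read differently at this carbonyl carbon.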